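Removing the bromo group from compound 1

The source may report more compounds than this note shows. Statements on the series, on what has been measured and on what is new or still open speak of the compounds shown alone.

In a functional assay on A549 cells (Homo sapiens) for antiproliferative activity, read by CCK-8 assay, with a stated time of 72 h (a higher number here means a weaker inhibitor, a lower number a stronger inhibitor), compound 1 `Nc1ccccc1NC(=O)c1ccc(COc2ccc(Br)cc2)cc1` gives 24400 nM, the higher of the two numeric values in this small set. Compound 2 `O=C(/C=C/c1ccc(CN2CCc3ccccc32)cc1)NO` gives 5480 nM, a lower number by more than the usual scatter. Compound 3 `Nc1ccccc1NC(=O)/C=C/c1ccc(COc2ccccc2)cc1` has no numeric value, only a limit of > 32000 nM.

The next compound to be tested is compound 4 `Nc1ccccc1NC(=O)c1ccc(COc2ccccc2)cc1`. It has hydrogen in place of bromo on an aromatic carbon, para to a large group, so that 4-bromophenoxy becomes phenoxy (hydrogen in place of bromo on an aromatic carbon). Within the data shown here, no measured pair isolates this change, so the expectation is only tentative. It leans on compound 3, which also carries a phenoxy group and whose reading is the limit of > 32000 nM. In this assay no step beyond the scatter is expected, with at most a slight drift toward a higher number. The expected change is a 1.2-fold higher number from compound 1 to compound 4 (0.09 log units; within the scatter). For compound 4 the estimated value is 30000 nM, with an expected range of 13000 nM to 65000 nM.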

Compound 4, half-maximal inhibitory concentration: 6760 nM
Estimate against measurement, compound 4: 4.4-fold (0.65 log units) above; the measured number lies below the stated range.
By their numbers in this assay, from the lowest: compounds 2 and 4 (each within the scatter of the next); then compound 1. At a limit, above all of these: compound 3.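

In this assay, bromo is not needed on this aromatic carbon of the 4-bromophenoxy group: replacing it with hydrogen gives a 3.6-fold lower number from compound 1 to compound 4 (0.56 log units; beyond the scatter). Among these compounds, this is the first step that isolates a single place, and it shows that the plain phenoxy group can give a measured number on the core of compound 1. Compound 3 also carries phenoxy, but its reading is only a limit, so phenoxy alone does not decide the outcome: the limit of > 32000 nM in this assay, at which 1 of the 4 values shown sits.

A chloro, methyl or methoxy group on the same carbon would show whether the step belongs to bromo alone or to any group there. From the compounds shown here alone, whether removing bromo has a similar effect on a core with the carbon-carbon double bond of compound 3 also remains open.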